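From methyl to phenyl on the compound 3 chain

The source may report more compounds than this note shows. Statements on the series, on what has been measured and on what is new or still open speak of the compounds shown alone.

- compound 1 `Cc1nc2cnccc2n1CC1CCN(C(=O)CC(C)c2ccc(N)cc2)CC1` gives 11 nM
- compound 2 `Cc1nc2cnccc2n1CC1CCN(C(=O)/C=C/c2ccc(N)cc2)CC1` gives 1200 nM
- compound 3 `C/C(=C\C(=O)N1CCC(Cn2c(C)nc3cnccc32)CC1)c1ccc(N)cc1` gives 60 nM

In a functional assay on the whole organism with Oryctolagus cuniculus as the target (on this read-out higher numbers stand for weaker inhibition and lower numbers for stronger inhibition), compound 3 stands at 60 nM and holds the middle place, with compound 1 lower and compound 2 higher, both gaps lying beyond the scatter. Compound 4 `Cc1nc2cnccc2n1CC1CCN(C(=O)/C=C(\c2ccccc2)c2ccc(N)cc2)CC1` is not yet measured. It differs from compound 3 by one change phenyl in place of methyl on a double-bonded chain carbon bound to an aromatic carbon and a double-bonded chain carbon with phenyl in place of methyl on a double-bonded chain carbon bound to an aromatic carbon and a double-bonded chain carbon.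

For the measured compounds named here, no measured pair shows this change on its own, so the expectation has little to rest on. The spread from compound 1 at 11 nM to compound 2 at 1200 nM also calls for a wide range. The expected move is a 1.5-fold higher number from compound 3 to compound 4 (0.18 log units; within the scatter) and is estimated to stay within the scatter, leaning slightly toward weaker inhibition. For compound 4 the estimate is 90 nM with an expected range from 15 nM to 500 nM in this assay once it is measured.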

Compound 4, half-maximal inhibitory concentration: 5 nM
Estimate against measurement, compound 4: 18-fold (1.26 log units) above; the measured number lies below the stated range.
By their numbers in this assay, from the lowest: compound 4; then compound 1; then compound 3; then compound 2.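

In this assay, for the compounds shown here, phenyl in place of methyl on a double-bonded chain carbon bound to an aromatic carbon and a double-bonded chain carbon gives a 12-fold lower number from compound 3 to compound 4 (1.08 log units; beyond the scatter), a large step and the first single-place change that can be read in this set. It shows that this position takes a six-membered aromatic ring of carbon only where a lone methyl stood, and that inhibition grows stronger rather than weaker with this exchange. Nothing available accounts for the size of this step.

The compounds shown leave open whether the gain needs an aromatic ring at all, since a cyclohexyl or an ethyl group at the same place would separate ring character from simple bulk. Also open, as far as these compounds go, are how a pyridyl ring or a chlorophenyl group would compare with phenyl, and whether phenyl would act alike on the saturated chain of compound 1.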